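The source may hold more compounds than are shown below. What is called first, only, known or untested is meant among the compounds shown, and "the series" means these compounds.

Compounds 1, 2 and 3 share one core, shown in compound 1 `Cn1c(-c2ccc(NC(=O)CSc3nc4cc(Cl)ccc4o3)cc2)nc(-c2ccccc2)c1-c1ccccc1`. In a functional assay on HT-29 cells (Homo sapiens) for cytotoxicity, read by MTT assay, with a stated time of 24 h, tested at 0.64 ug/mL (a higher number here means a stronger effect of the compound at the concentration tested, a lower number a weaker effect), compound 1 gives 11.9%. Compound 2 `Cc1ccc2oc(SCC(=O)Nc3ccc(-c4nc(-c5ccccc5)c(-c5ccccc5)n4C)cc3)nc2c1` gives 11% in this assay, and compound 3 `CN(C)/C=C/N1CCN(CC(=O)Nc2ccc(-c3nc(-c4ccccc4)c(-c4ccccc4)n3C)cc2)CC1` gives 3.1% in this assay. The number of compound 3 is the smallest of the three, yet both gaps to it, a number 8.8 percentage points lower from compound 1 to compound 3 (within the scatter) and a number 7.9 percentage points lower from compound 2 to compound 3 (within the scatter), lie within the scatter. Compound 4 `Cc1ccc(CN2CCN(CC(=O)Nc3ccc(-c4nc(-c5ccccc5)c(-c5ccccc5)n4C)cc3)CC2)cc1` differs from compound 3 in one place: 4-methylbenzyl in place of 2-(dimethylamino)ethenyl on an amine nitrogen in a ring. Among the compounds with values here, no measured pair exchanges a group on the amine nitrogen in the ring, so only those two steps bear on it, and neither was beyond the scatter. The step of a number 4.9 percentage points higher from compound 3 to compound 4 (within the scatter) is therefore expected to stay within the scatter. For compound 4 the estimated value in this assay is 8%, within 0% to 25%.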

Compound 4, a percentage reported as activity, at one concentration (the size of the read-out at that concentration, not a potency): 15.4%
Compound 4: middle estimate off by 7.4 percentage points, on the low side; low and high end bracket the measured number.
By their numbers in this assay, from the lowest: compounds 3, 2, 1 and 4 (each within the scatter of the next, the first and the last beyond it).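

Within the data shown here, on the amine nitrogen in the ring, a single exchange now moves the read-out in this assay beyond the scatter, which no earlier step did: a number 12.3 percentage points higher from compound 3 to compound 4 (beyond the scatter). The change puts 4-methylbenzyl, with its six-membered aromatic ring of carbon only, in place of 2-(dimethylamino)ethenyl, but this modest step rests on one pair. Nothing measured here accounts for the step.

From the compounds shown here alone, it remains open whether the aromatic ring or its methyl carries the step. Plain benzyl or 4-chlorobenzyl on the same nitrogen would separate the two.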